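A few compounds are considered here, and "the series" means these few. Any claim that something is new, unique, unknown or untested is made for them only; others in the source may bear on it.

Measured so far:
- compound 1 `O=C(NNc1ccccc1Cl)c1ccccc1NS(=O)(=O)c1cnc(O)nc1O`: 5480 nM
- compound 2 `Cc1ccccc1C(=O)NNC(=O)c1cccc(NS(=O)(=O)c2cnc(O)nc2O)c1`: 8010 nM

Of the compounds shown here, two have been tested in a functional assay on A549 cells (Homo sapiens) for antiproliferative activity, read by MTT assay, with a stated time of 24 h (a higher number here means a weaker inhibitor, a lower number a stronger inhibitor), so far. In this test, compound 1 gives 5480 nM and compound 2 gives 8010 nM as its result. These two numbers lie within the usual scatter of repeated measurements, so compound 1 cannot be separated from compound 2 on these data.

The next compound to be tested is compound 3 `O=C(NNC(=O)c1ccccc1NS(=O)(=O)c1cnc(O)nc1O)c1ccccc1Cl`, which is built from compound 1 by a single change on the side of the molecule that carries the chlorine. That change is (2-chlorophenyl)carbonyl in place of 2-chlorophenyl on an amine nitrogen, so (2-chlorophenyl)carbonyl takes the place of 2-chlorophenyl on an amine nitrogen. The ring and its chlorine stay, while a carbonyl is added to the link.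

Among the measured compounds shown here, no measured pair of compounds shows what a change of this kind does in this assay, so the data give no size or direction for it. For the measured compounds named here, the only guide is that the two known values sit close together, and no step beyond the scatter is expected in either direction. The estimate for the change is a 1.3-fold higher number from compound 1 to compound 3 (0.11 log units; within the scatter) in this test. For compound 3 the estimated value is 7000 nM with an expected range from 2500 nM to 20000 nM in this test.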

Compound 3, half-maximal inhibitory concentration: 5290 nM
Compound 3: the middle estimate sits 1.3-fold (0.12 log units) above what was measured, within the range that was stated.
By their numbers in this assay, from the lowest: compounds 3, 1 and 2 (each within the scatter of the next).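

In this assay, among the compounds shown here, this is the first measured step at this place: (2-chlorophenyl)carbonyl in place of 2-chlorophenyl on an amine nitrogen gives a 1.0-fold lower number from compound 1 to compound 3 (0.02 log units; within the scatter), so the two compounds cannot be told apart. This pair shows that a carbonyl can enter the link, with the ring and its chlorine kept, while the result stays within the scatter of repeated measurements. This is a statement about the numbers only, as no further data bear on what lies behind this result.

Going by these compounds, a single step at a single place does not show how other groups would behave there, so it remains open whether a simple amine, a carboxylic acid or a longer chain on this amine nitrogen would give a number in the same range or a clearly different one. On these data alone, it is also open whether the chlorine matters for this result, which a plain phenyl group in its place, with and without the carbonyl, would help to show.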